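Chloro for cyano on the benzyl ring of compound 3

The source may report more compounds than this note shows. Statements on the series, on what has been measured and on what is new or still open speak of the compounds shown alone.

Compound 1 `COC(=O)[C@H](CCSC)NC(=O)c1ccc(NCc2cncn2Cc2cccc(C#N)c2)cc1-c1ccccc1` gives in a functional assay on NIH3T3 cells (Mus musculus) (on this read-out higher numbers stand for an effect only at larger amounts of compound and lower numbers for an effect already at smaller amounts), only a limit, > 10 uM.
Compound 2 `CSCC[C@H](NC(=O)c1ccc(NCc2cncn2Cc2ccccc2Cl)cc1-c1ccccc1)C(=O)O` gives in this assay only a limit, > 10 uM.
Compound 3 `COC(=O)[C@H](CCSC)NC(=O)c1ccc(NCc2cncn2Cc2ccccc2C#N)cc1-c1ccccc1` gives in this assay only a limit, > 10 uM.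

Compound 3 thus stands at a limit rather than at a number, and so do the other two compounds shown. Going by the values given here, the one measured step, a step that the two limits leave unreadable from compound 1 to compound 3, cannot be read, since both of its ends are limits. The change to compound 4 `COC(=O)[C@H](CCSC)NC(=O)c1ccc(NCc2cncn2Cc2ccccc2Cl)cc1-c1ccccc1` is chloro in place of cyano on an aromatic carbon. Among the compounds with values here, no measured step bears on this change in a readable way; compound 2, which carries the same 2-chlorobenzyl group on the free acid, sits at its limit as well. Within the data shown here, the only evidence is the limit of > 10 uM in this assay, at which 3 of the 3 values shown sit, and it gives no direction. For this assay compound 4 is therefore expected to remain near that limit, with an estimate of 15 uM and a range from 5 uM to 50 uM. The step this estimate means is expected to be a step that the limit leaves unreadable from compound 3 to compound 4, nothing beyond the scatter.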

Compound 4, concentration for half-maximal effect: > 10 uM
Compound 4: a limit, no number (the forecaster's own chance of this, stated with the estimate: 80%); the middle value lies beyond the limit too.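

Compound 4 also gives only a limit in this assay, so its steps from compound 1, compound 2 and compound 3 cannot be read. The compounds shown leave open whether chloro in place of cyano, or methyl in place of hydrogen on the oxygen, changes the read-out at all: the limit of > 10 uM in this assay, at which 4 of the 4 values shown sit.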